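Exchanging One Aromatic Group in a Close Pair

The source may hold more compounds than are shown below. What is called first, only, known or untested is meant among the compounds shown, and "the series" means these compounds.

In a functional assay on A-375 cells (Homo sapiens) for activation, with a stated time of 3 days (on this read-out lower numbers stand for an effect already at smaller amounts and higher numbers for an effect only at larger amounts of compound), compound 1 (`O=C(Nc1ccc(-c2cscn2)cc1)C1CCCN(Cc2ccc(F)cc2)C1`) gives 5000 nM and compound 2 (`O=C(Nc1ccc(-c2cscn2)cc1)C1CCCN(Cc2ccc(Cl)c(Cl)c2)C1`) gives 3000 nM on the same read-out, so these two values lie within the usual scatter of each other. The unmeasured compound 3 (`O=C(Nc1ccc(-c2cscn2)cc1)C1CCCN(Cc2cccc(C(F)(F)F)c2)C1`) keeps the shared core and carries 3-(trifluoromethyl)phenyl in place of 3,4-dichlorophenyl on a saturated chain carbon bound to an amine nitrogen in a ring. Within the data shown here, the one measured step at this place (a 1.7-fold lower number from compound 1 to compound 2 (0.22 log units; within the scatter)) puts 3,4-dichlorophenyl in place of 4-fluorophenyl, so no step beyond the scatter is expected in this assay for the new exchange, although a single step is thin support. The expected step is small (a 1.2-fold higher number from compound 2 to compound 3 (0.07 log units; within the scatter)) and may point either way. For compound 3 the estimated value is 3500 nM with an expected range of 1200 nM to 10000 nM for the coming measurement.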

Compound 3, half-maximal effective concentration: > 20000 nM
Compound 3: a limit, no number; the forecaster's own chance of this, stated with the estimate: 15%; middle value at least 5.7-fold (0.75 log units) away from the limit.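

Compound 1 and compound 2 lie within the usual scatter of each other, so the change from 4-fluorophenyl to 3,4-dichlorophenyl on a saturated chain carbon bound to an amine nitrogen in a ring gave no sign that this aromatic group matters. Compound 3 now shows that it does in this assay, with an at least 6.6-fold higher number from compound 2 to compound 3 (0.82 log units; beyond the scatter) and an at least 4.0-fold higher number from compound 1 to compound 3 (0.60 log units; beyond the scatter), so an exchange at this place can move the read-out beyond the scatter. The result for compound 3 is a limit of the assay and not a number, and the full size of both steps stays unknown: the limit of > 20000 nM in this assay, at which 1 of the 3 values shown sits.

Still open, going by these compounds, is whether this shift follows the trifluoromethyl group itself or the spot it holds on the aromatic ring. A 4-(trifluoromethyl)phenyl or a 3-chlorophenyl group at this place would help to tell these two readings apart.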